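A Methyl on the Piperidine Ring of Compound 2

The compounds below may be only part of what the source reports. "The series", "measured", "known", "first", "only" and "open" are said of these compounds alone.

Measured compounds:
Compound 1 `CCN(CC)CCCOc1cc2ncnc(Nc3nc4ccc(C(=O)Nc5c(C)cccc5C)cc4s3)c2cc1OC`: 28400 nM
Compound 2 `COc1cc2c(Nc3nc4ccc(C(=O)Nc5c(C)cccc5C)cc4s3)ncnc2cc1OCCCN1CCCCC1`: 13700 nM

Of the compounds shown here, two have been tested in a functional assay on K562 cells (Homo sapiens) for cytotoxicity, read by WST assay, with a stated time of 72 h; on this read-out lower numbers stand for stronger inhibition and higher numbers for weaker inhibition. Compound 1 gives 28400 nM, and compound 2 gives 13700 nM. These two share the same core and differ only in the amine at the end of the three-carbon chain. Among the measured compounds shown here, the single measured step is a 2.1-fold lower number from compound 1 to compound 2 (0.32 log units; beyond the scatter). For the measured compounds named here, on these numbers compound 2 holds the lower value of the two, and compound 1 is its only neighbour.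

Compound 3 `COc1cc2c(Nc3nc4ccc(C(=O)Nc5c(C)cccc5C)cc4s3)ncnc2cc1OCCCN1CCCCC1C` is the next compound. It differs from compound 2 by methyl in place of hydrogen on a saturated ring carbon. Going by the values given here, no measured step touches a ring carbon of the piperidine; the one known step, a 2.1-fold lower number from compound 1 to compound 2 (0.32 log units; beyond the scatter), exchanged the whole amine and was modest in size. The measured data therefore offer no direct guide for a methyl on the ring. The expectation is a small step of a 1.1-fold lower number from compound 2 to compound 3 (0.06 log units; within the scatter) in this assay, likely within the scatter, with a lower number only slightly favoured. The estimated value for compound 3 in this assay is 12000 nM, with a range from 4500 nM to 32000 nM.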

Compound 3, half-maximal inhibitory concentration: 12300 nM
Estimate against measurement, compound 3: 1.0-fold (0.01 log units) below; measured number inside the range.
By their numbers in this assay, from the lowest: compounds 3 and 2 (each within the scatter of the next); then compound 1.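

In this assay, placing a methyl on the saturated ring carbon next to the ring nitrogen, the change from piperidin-1-yl to 2-methylpiperidin-1-yl, gives a 1.1-fold lower number from compound 2 to compound 3 (0.05 log units; within the scatter), so at this position the added carbon leaves the read-out indistinguishable from that of the unsubstituted ring. The advantage of the ring amine over diethylamino therefore survives the methyl: with 2-methylpiperidin-1-yl in place of diethylamino, the comparison shows a 2.3-fold lower number from compound 1 to compound 3 (0.36 log units; beyond the scatter), a modest step about as large as the one seen with the plain piperidine. No measured information on these compounds explains this result, so the numbers describe what happens without showing the reason for it.

One methyl at one ring position says little about the rest of the ring, so a methyl on a carbon further from the ring nitrogen, or an ethyl at this same carbon, could behave differently. As far as these compounds go, it also remains open how a morpholine or a piperazine at the end of the chain, or a longer chain between the oxygen and the amine, would compare with compound 2 and compound 3.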